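The compounds below may be only part of what the source reports. "The series", "measured", "known", "first", "only" and "open" are said of these compounds alone.

In a functional assay on T98G cells (Homo sapiens) for inhibition, read by MTT assay, with a stated time of 72 h (a higher number here means a weaker inhibitor, a lower number a stronger inhibitor), compound 1 (`COc1ccc(NC(=S)NC2CC(C)(C)Oc3ccc(Br)cc32)cc1`) gives 33000 nM and compound 2 (`CC1(C)CC(NC(=S)Nc2cccc([N+](=O)[O-])c2)c2cc(Br)ccc2O1`) gives 4000 nM as its half-maximal inhibitory concentration. Compound 2 holds the lower of these two numbers, and its gap to compound 1 lies beyond the usual scatter, so it stands as the stronger inhibitor of the pair. Compound 3 (`CC1(C)CC(NC(=S)Nc2cccc(Cl)c2)c2cc(Br)ccc2O1`) has not yet been measured in this assay. It has chloro in place of nitro on an aromatic carbon and is otherwise the same as compound 2. The two measured compounds do not form a pair that differs in one place, so the data give no direct guide to the size of this exchange. The expectation therefore starts from compound 2 at 4000 nM as the closest measured structure. The expected change is a 1.5-fold higher number from compound 2 to compound 3 (0.18 log units; within the scatter) in the direction of a slightly weaker inhibitor, and it is not expected to clear the scatter. For compound 3 the estimate is 6000 nM with 2000 nM to 20000 nM as the expected range.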

Compound 3, half-maximal inhibitory concentration: 9000 nM
For compound 3 the middle estimate is 1.5-fold (0.18 log units) below the measured one; the measured number falls inside the stated range.
By their numbers in this assay, from the lowest: compound 2; then compound 3; then compound 1.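

In this assay, chloro in place of nitro on an aromatic carbon, meta to a large group, gives a 2.3-fold higher number from compound 2 to compound 3 (0.35 log units; beyond the scatter). Within the data shown here, this is the first direct measure at this position: the change is modest but beyond the usual scatter, and the nitro group is not required for a measurable effect, since the single chlorine atom still leaves a number in the same broad region. Among these compounds, the second exchange, 3-chlorophenyl in place of 4-methoxyphenyl on an amide-type nitrogen, gives a 3.7-fold lower number from compound 1 to compound 3 (0.56 log units; beyond the scatter), which shows for the first time, with the rest of the core held fixed, that the choice of this aromatic group alone moves the number, although no measurement here explains either step.

From the compounds shown here alone, whether an amine, a methyl group or a carboxylic acid on this same aromatic carbon would give a lower or a higher number remains open. Going by these compounds, it is also open whether chloro and nitro would keep the same order on another carbon of that ring, or with the bromo group of the shared core replaced by another halogen such as fluoro.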